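A few compounds are considered here, and "the series" means these few. Any claim that something is new, unique, unknown or untested is made for them only; others in the source may bear on it.

Compound 3 `CC1CC/C(=N\Nc2cccc(Cl)c2)c2ncc(C(=O)O)c(=O)n21` reaches in a functional assay on the whole organism for inhibition, with Rattus norvegicus as the target (a higher number here means that more compound is needed for the effect, a lower number that less compound is needed), only a limit, > 100 umol/kg. The other measured compounds give no firmer footing. Compound 2 `CC1CC/C(=N\Nc2ccccc2F)c2ncc(C(=O)O)c(=O)n21` gives in this assay a limit, > 1000 umol/kg. Compound 1 `CC1CC/C(=N\Nc2ccccc2)c2ncc(C#N)c(=O)n21` likewise gives a limit, > 1000 umol/kg. Among the measured compounds shown here, the one step between measured compounds, a step that the two limits leave unreadable from compound 2 to compound 3, therefore cannot be read in size, and the limit of > 100 umol/kg in this assay, at which 1 of the 3 values shown sits, together with the limit of > 1000 umol/kg in this assay, at which 2 of the 3 values shown sit, is all the evidence the series offers. Compound 4 `CC1CC/C(=N\Nc2cccc(Br)c2)c2ncc(C(=O)O)c(=O)n21` differs from compound 3 by bromo in place of chloro on an aromatic carbon. For the measured compounds named here, no measured step covers such an exchange, so no shift beyond the usual scatter is expected. Compound 4 is estimated at 300 umol/kg, between 100 umol/kg and 1000 umol/kg. This expectation amounts to a step that the limit leaves unreadable from compound 3 to compound 4, with a strong chance that only a limit is again reported.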

Compound 4, dose for 50% inhibition: > 320 umol/kg
Compound 4 ended at the assay's limit; the forecaster's own chance of this, stated with the estimate: 80%; at least 1.0-fold (0.02 log units) between middle value and limit.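

Compound 4 also gives only a limit in this assay, > 320 umol/kg, and its steps from compound 3 and from compound 2 cannot be read. The compounds shown leave open whether bromo and chloro differ at all in this assay, and what dose any of these compounds would need for the effect.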